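A few compounds are considered here, and "the series" means these few. Any claim that something is new, unique, unknown or untested is made for them only; others in the source may bear on it.

Compound 1 `CCCS(=O)(=O)c1cccc(C#Cc2cc(Cl)ccc2OCC(=O)O)c1` is the starting point here; in an assay on CHO cells for displacement of a labelled ligand from prostaglandin D2 receptor 2 (Homo sapiens), read by scintillation counting (on this read-out lower numbers stand for stronger inhibition and higher numbers for weaker inhibition), compound 1 gives 9 nM. Compound 2 `CCCS(=O)(=O)c1cccc(C#Cc2cc(F)ccc2OCC(=O)O)c1` carries fluoro in place of chloro on an aromatic carbon, and in this assay compound 2 gives 65 nM, a step of a 7.2-fold higher number from compound 1 to compound 2 (0.86 log units; beyond the scatter). Compound 3 `CS(=O)(=O)c1ccc(Cl)c(C#Cc2cc(Cl)ccc2OCC(=O)O)c1` gives 3.5 nM in this assay, the lowest of the three numbers; how its core differs from that of compound 1 is not broken down here. Compound 4 `CS(=O)(=O)c1ccc(F)c(C#Cc2cc(Cl)ccc2OCC(=O)O)c1` carries fluoro in place of chloro on an aromatic carbon. This is the same kind of change as before, though its surroundings differ: here the position is ortho to a large group and para to a methylsulfonyl group, whereas before it was meta to a large group and para to a carboxymethoxy group. A weakening of similar size is expected, a 4.3-fold higher number from compound 3 to compound 4 (0.63 log units; beyond the scatter), because a 7.2-fold higher number from compound 1 to compound 2 (0.86 log units; beyond the scatter) showed this kind of change raising the number. Compound 4 is therefore estimated at 15 nM, between 5 nM and 50 nM.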

Compound 4, inhibition constant: 3.3 nM
For compound 4 the middle estimate is 4.5-fold (0.66 log units) above the measured one; measured number outside the range, below it.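

Fluoro in place of chloro gives a 1.1-fold lower number from compound 3 to compound 4 (0.03 log units; within the scatter), so the two compounds cannot be told apart in this assay. Set beside the earlier case, the same swap does not carry over as a fixed step from one core to another in this series: the same change on two cores in this assay, a 7.2-fold higher number (0.86 log units; beyond the scatter) from compound 1 to compound 2 and a 1.1-fold lower number (0.03 log units; within the scatter) from compound 3 to compound 4, 7.7-fold (0.88 log units) apart, beyond the scatter of two such steps. These two pairs show that the size of the step can differ with its surroundings, but not which difference between the cores matters, as the swaps sit in different places and the cores differ in more than one feature.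

Still open, on these data alone, is which of the two steps a further core would follow. So is how a nitrile or a methoxy group would compare with the fluoro of compound 4 at that place.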